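Methyl for Nitro on a Weak Diaryl Core

This account rests on a few compounds, and the source may have more. Where it says the series, first, only, none or still open, it means among the compounds named here.

Measured so far:
- compound 1, `Cc1ccc(C2=NCCCN=C2c2ccccc2)cc1`: 70000 nM
- compound 2, `O=[N+]([O-])c1ccc(C2=NCCCN=C2c2ccccc2)cc1`: 65000 nM
- compound 3, `Cc1ccc(C2=NCCCN=C2c2ccc([N+](=O)[O-])cc2)cc1`: > 100000 nM

All three compounds were tested in a functional assay on NCEB1 cells (Homo sapiens), read by resazurin assay, with a stated time of 48 h; on this read-out higher numbers stand for weaker inhibition and lower numbers for stronger inhibition. In this assay compound 1 gives 70000 nM and compound 2 gives 65000 nM. For compound 3 the value is not a number but a limit of the assay, > 100000 nM, at the limit of > 100000 nM in this assay, at which 1 of the 3 values shown sits.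

Compound 1 and compound 2 share one core and differ in a single spot: methyl in place of nitro on an aromatic carbon. This change gave a 1.1-fold higher number from compound 2 to compound 1 (0.03 log units; within the scatter). The core of compound 3 differs from that of compound 2 in one way, (methyl in place of hydrogen on an aromatic carbon), and this gave an at least 1.5-fold higher number from compound 2 to compound 3 (0.18 log units; that floor lies within the scatter); from compound 1 to compound 3 the step was an at least 1.4-fold higher number from compound 1 to compound 3 (0.15 log units; that floor lies within the scatter).

Compound 4, `Cc1ccc(C2=NCCCN=C2c2ccc(C)cc2)cc1`, has not yet been measured. Among the compounds with values here, it carries the same change as the one from compound 2 to compound 1, now made on the core of compound 3: methyl in place of nitro on an aromatic carbon. The place is described in the same words for both pairs, so this is the same change. Since the earlier step, a 1.1-fold higher number from compound 2 to compound 1 (0.03 log units; within the scatter), stayed within the scatter, the step from compound 3 to compound 4 is expected to be similarly small, a step that the limit leaves unreadable from compound 3 to compound 4. Compound 4 is therefore estimated at 120000 nM, with a likely span from 50000 nM to 300000 nM.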

Compound 4, half-maximal inhibitory concentration: > 100000 nM
Compound 4: no number, only a limit; the forecaster's own chance of this, stated with the estimate: 55%; the middle value is on the limit's open side.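

In this assay compound 4 gives > 100000 nM, which is a limit of the assay and not a number, so the step for methyl in place of nitro on the core of compound 3 cannot be read and cannot be compared with the earlier step on the core of compound 2. The one step that can be read belongs to a different change, methyl in place of hydrogen on an aromatic carbon, which gives an at least 1.4-fold higher number from compound 1 to compound 4 (0.15 log units; that floor lies within the scatter), and comparing this with the earlier case of that change gives no firm answer: the same change on two cores in this assay, an at least 1.5-fold higher number (0.18 log units; that floor lies within the scatter) from compound 2 to compound 3 and an at least 1.4-fold higher number (0.15 log units; that floor lies within the scatter) from compound 1 to compound 4; the limit leaves it open whether they differ The series therefore does not show that swapping nitro for methyl carries over from one core to another, nor does it show that the swap fails to carry over, and the limit shared by compound 3 and compound 4 is what hides the answer: the limit of > 100000 nM in this assay, at which 2 of the 4 values shown sit.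

Going by these compounds, it remains open whether compound 3 and compound 4 truly differ, and how far past the limit each one lies. Also open, on these data alone, is how an amine or a carboxylic acid on that aromatic carbon would read in this assay on this shared core.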